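The compounds below may be only part of what the source reports. "The series", "measured", "known", "first", "only" and "open" are said of these compounds alone.

Compound 3 `C=C1C[C@]23C[C@@]1(O)CC[C@H]2c1ccc(O)c(C)c1[C@@H]3Cn1cc(-c2ccc(C(F)(F)F)cc2)nn1` gives, in a functional assay on SMMC-7721 cells (Homo sapiens) for cytotoxicity, read by MTT assay, with a stated time of 4 days (a higher number here means a weaker inhibitor, a lower number a stronger inhibitor), only a limit of > 20000 nM. Compound 1 `C=C1C[C@]23C[C@@]1(O)CC[C@H]2c1ccc(O)c(C)c1[C@@H]3Cn1cc(-c2ccccn2)nn1` likewise reaches only the limit of > 20000 nM in this assay. Compound 2 `C=C1C[C@]23C[C@@]1(O)CC[C@H]2c1ccc(OS(=O)(=O)c2ccc(C)cc2)c(C)c1[C@@H]3Cn1cc(-c2ccc(Br)cc2)nn1` also stops at the limit of > 20000 nM. Going by the values given here, every value shown therefore sits at the same limit, (the limit of > 20000 nM in this assay, at which 3 of the 3 values shown sit), and the one single-site step recorded, a step that the two limits leave unreadable from compound 1 to compound 3, cannot be read. Compound 4 `C=C1C[C@]23C[C@@]1(O)CC[C@H]2c1ccc(O)c(C)c1[C@@H]3Cn1cc(-c2ccc(Br)cc2)nn1` differs from compound 3 by bromo in place of trifluoromethyl on an aromatic carbon. Among the compounds with values here, no measured step bears on this change, and the only neighbouring step gives no size, so the expected step that the limit leaves unreadable from compound 3 to compound 4 is none that can be told apart from the scatter. Compound 4 is estimated at 30000 nM, within 8000 nM to 120000 nM, and is expected most likely to be reported again only as a limit.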

Compound 4, half-maximal inhibitory concentration: > 20000 nM
Compound 4: a limit, no number (the forecaster's own chance of this, stated with the estimate: 80%); the middle value lies beyond the limit too.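

Going by these compounds alone, no step from compound 1, compound 2 or compound 3 to compound 4 can be read, since all four compounds stop at one limit: the limit of > 20000 nM in this assay, at which 4 of the 4 values shown sit. The compounds shown leave open how large any of these changes is in this assay.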